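Pyrimidinyl sulfonamide series: heteroaryl swap on the chromane arm

The source may report more compounds than this note shows. Statements on the series, on what has been measured and on what is new or still open speak of the compounds shown alone.

Measured so far:
- compound 1 `Cn1nccc1-c1cc(C(F)(F)F)ccc1[C@H]1CCc2cc(S(=O)(=O)Nc3ncccn3)ccc21`: 315 nm/s
- compound 2 `O=S(=O)(Nc1ncccn1)c1ccc2c(c1)OCC[C@@H]2c1ccc(C(F)(F)F)cc1-c1ccc(F)nc1`: 418 nm/s

In an ADME assay on Caco-2 cells (Homo sapiens) for permeability, in the apical to basolateral direction (on this read-out lower numbers stand for lower permeability and higher numbers for higher permeability), compound 2 gives 418 nm/s, the higher of the two numbers, and compound 1 gives 315 nm/s; the gap between them is within the scatter, so the two compounds are not separated by this assay.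

Compound 3 `Cn1nccc1-c1cc(C(F)(F)F)ccc1[C@H]1CCOc2cc(S(=O)(=O)Nc3ncccn3)ccc21` is not yet measured. It differs from compound 2 in one place: 1-methyl-1H-pyrazol-5-yl in place of 6-fluoropyridin-3-yl on an aromatic carbon. Within the data shown here, no step between measured compounds covers this change, so its direction has to be judged from compound 2 alone and from the general level of the series, which sits within one band for both measured compounds.

The expectation is that the step from compound 2 to compound 3 stays small, within the scatter, with no clear direction, so that a 1.2-fold lower number from compound 2 to compound 3 (0.09 log units; within the scatter) is the estimated change. For compound 3 the expected value in this assay is 340 nm/s, with a range from 180 nm/s to 620 nm/s.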

Compound 3, apparent permeability: 280 nm/s
Estimate against measurement, compound 3: 1.2-fold (0.08 log units) above; the range from low to high includes it.
By their numbers in this assay, from the lowest: compounds 3, 1 and 2 (each within the scatter of the next).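

In this assay the swap of 6-fluoropyridin-3-yl for 1-methyl-1H-pyrazol-5-yl gives a 1.5-fold lower number from compound 2 to compound 3 (0.17 log units; within the scatter), so this assay does not separate the two compounds. Among these compounds, this is the first single-place comparison at this aromatic carbon, ortho to a large group and meta to a trifluoromethyl group, and it shows that a six-membered aromatic ring with 1 hetero atom and a five-membered aromatic ring with 2 hetero atoms can stand there without a difference that this read-out can resolve. No supporting measurement bears on this result, so it remains a plain observation on one pair.

The compounds shown carry only aromatic rings at this carbon, so how an amine, a carboxylic acid or a nitrile would read there remains open. The core of compound 1 appears here only with 1-methyl-1H-pyrazol-5-yl, so whether the same swap would also stay within the scatter on that core is likewise unresolved.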